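The compounds below may be only part of what the source reports. "The series", "measured", "known", "first", "only" and "open" are said of these compounds alone.

Measured so far in a functional assay on PC-3 cells (Homo sapiens) for cytotoxicity, read by sulforhodamine B assay, with a stated time of 48 h, tested at 100 uM; on this read-out higher numbers stand for a weaker effect at the one concentration tested and lower numbers for a stronger effect:
compound 1 `COc1ccc(-c2cc(/C=C/C(=O)c3ccc(N)cc3)[nH]n2)cc1`, -83%
compound 2 `COc1cc(-c2cc(/C=C/C(=O)c3ccc(Cl)c(Cl)c3)[nH]n2)cc(OC)c1OC`, 10%
compound 3 `COc1cc(-c2cc(/C=C/C(=O)c3ccc(F)c(F)c3)[nH]n2)cc(OC)c1OC`, -41%

Compound 1 stands lowest of the three numbers; compound 3 lies nearer to it, compound 2 furthest, both gaps beyond the scatter. Compound 4 `COc1ccc(-c2cc(/C=C/C(=O)c3ccc(N)cc3)[nH]n2)cc1OC` differs from compound 1 by methoxy in place of hydrogen on an aromatic carbon, placed ortho to a methoxy group on the six-membered aromatic ring of carbon only.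

Within the data shown here, the only measured single step, a number 51 percentage points lower from compound 2 to compound 3 (beyond the scatter), concerns the aryl on the carbonyl carbon, not the ring changed here, so it does not bear on this step. Compounds 2 and 3 carry more methoxy groups than compound 1 but also differ elsewhere, so their values give no clean comparison. No step beyond the scatter is expected in this assay; the estimate is a number 8 percentage points higher from compound 1 to compound 4 (within the scatter), giving compound 4 an expected -75%, range -100% to -40%.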

Compound 4, a percentage reported as activity, at one concentration (the size of the read-out at that concentration, not a potency): -48%
The estimate for compound 4 lay 27 percentage points below the measured number; low and high end bracket the measured number.
By their numbers in this assay, from the lowest: compound 1; then compounds 4 and 3 (each within the scatter of the next); then compound 2.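

In this assay methoxy in place of hydrogen, ortho to a methoxy group, gives a number 35 percentage points higher from compound 1 to compound 4 (beyond the scatter) and so weakens the effect at the one concentration tested. This aromatic carbon is therefore sensitive to substitution: a group of 2 heavy atoms is enough to move the read-out beyond the scatter. Nothing measured on these compounds accounts for the step.

Open, on these data alone, is whether a hydroxy group, an ethoxy group or a fluorine atom at this place shifts the number as far. Also open, as far as these compounds go, is whether the step holds with another aryl on the carbonyl carbon.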